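This account rests on a few compounds, and the source may have more. Where it says the series, first, only, none or still open, it means among the compounds named here.

Three compounds share one core and differ only in the group carried on the amine nitrogen in the ring. Compound 1 `NC(=O)c1c(NC(=O)c2ccccc2Cl)sc2c1CCN(Cc1ccccc1)C2` gives 14500 nM in a functional assay on MKN-74 cells (Homo sapiens) for antiproliferative activity, with a stated time of 24 h; a higher number here means a weaker inhibitor, a lower number a stronger inhibitor. Compound 2 `Cc1ccccc1NC(=S)N1CCc2c(sc(NC(=O)c3ccccc3Cl)c2C(N)=O)C1` gives 11700 nM in this assay, and compound 3 `CSc1ccccc1NC(=S)N1CCc2c(sc(NC(=O)c3ccccc3Cl)c2C(N)=O)C1` gives 13800 nM. Among these three numbers compound 3 holds the second highest; the gap to compound 1 is the smaller one and the gap to compound 2 the larger, and both lie within the scatter. The steps of a 1.2-fold lower number from compound 1 to compound 2 (0.09 log units; within the scatter) and a 1.1-fold lower number from compound 1 to compound 3 (0.02 log units; within the scatter) show that replacing the whole group on that nitrogen hardly moved the number, and the step of a 1.2-fold higher number from compound 2 to compound 3 (0.07 log units; within the scatter) shows the same for a change on the aromatic ring itself.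

Compound 4 `COc1ccc(NC(=S)N2CCc3c(sc(NC(=O)c4ccccc4Cl)c3C(N)=O)C2)cc1` differs from compound 3 in one place: 4-methoxyphenyl in place of 2-(methylsulfanyl)phenyl on an amide-type nitrogen. The measured steps that bear on it all stayed within the scatter, so no step beyond the scatter is expected here, in either direction. Compound 4 is therefore expected to give 13000 nM in this assay, within a range from 6000 nM to 28000 nM, which corresponds to an expected step of a 1.1-fold lower number from compound 3 to compound 4 (0.03 log units; within the scatter).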

Compound 4, half-maximal inhibitory concentration: 19600 nM
Compound 4: the middle estimate sits 1.5-fold (0.18 log units) below what was measured, and the stated range covers the measured number.
By their numbers in this assay, from the lowest: compounds 2, 3, 1 and 4 (each within the scatter of the next).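

Changing the whole aryl group on the amide-type nitrogen, rather than only a small group on it, still leaves the result within the scatter in this assay: the step is a 1.4-fold higher number from compound 3 to compound 4 (0.15 log units; within the scatter). The other two comparisons, a 1.7-fold higher number from compound 2 to compound 4 (0.22 log units; within the scatter) and a 1.4-fold higher number from compound 1 to compound 4 (0.13 log units; within the scatter), also stay within the scatter, so no step among these four compounds separates them, even though 4-methoxyphenyl carries oxygen where 2-(methylsulfanyl)phenyl carries sulfur and has its substituent at a different ring position. No supporting measurements are available to explain these numbers.

Since the atom and its ring position change together, 2-methoxyphenyl or 4-(methylsulfanyl)phenyl would be needed to separate the two changes. Going by these compounds, whether any group here can move the number beyond the scatter remains open, for example a phenyl ring bearing an amine or a carboxylic acid, or a longer alkyl chain in place of the ring.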